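Methyl in Place of Nitro on a Pyridyl Urea

This account rests on a few compounds, and the source may have more. Where it says the series, first, only, none or still open, it means among the compounds named here.

Measured so far in a functional assay on the whole organism with Mus musculus as the target, in the maximal electroshock model, with a stated time of 30 min; a higher number here means that more compound is needed for the effect, a lower number that less compound is needed:
- compound 1, `O=C(Nc1ccncc1)Nc1ccccc1Br`: in this assay compound 1 gives 100 mg/kg
- compound 2, `CC(C)c1ccccc1NC(=O)Nc1ccncc1`: in this assay compound 2 gives 100 mg/kg
- compound 3, `O=C(Nc1ccncc1)Nc1ccc([N+](=O)[O-])cc1`: in this assay compound 3 gives > 300 mg/kg

The value of compound 3 is a limit of this assay and not a number, the point (the limit of > 300 mg/kg in this assay, at which 1 of the 3 values shown sits). Compound 1 and compound 2 both reached an effect; the step of no change at the digits printed from compound 1 to compound 2 (within the scatter) concerns a change at a different place on the shared core and does not touch the group that changes here.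

Compound 4, `Cc1ccc(NC(=O)Nc2ccncc2)cc1`, has not been measured. It differs from compound 3 by methyl in place of nitro on an aromatic carbon. Among the compounds with values here, no measured step involves the nitro group or the methyl group, so the only guide is that compound 3 sits at a limit while compound 1 and compound 2 gave numbers. Compound 4 is therefore expected to come in at about 100 mg/kg, between 30 mg/kg and 300 mg/kg. This estimate means an expected step of an at least 3.0-fold lower number from compound 3 to compound 4 (0.47 log units; beyond the scatter), down from the limit seen for compound 3.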

Compound 4, minimum effective dose: > 300 mg/kg
Compound 4 ended at the assay's limit (the forecaster's own chance of this, stated with the estimate: 30%); middle value at least 3.0-fold (0.47 log units) away from the limit.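

Compound 3 and compound 4 both stand at a limit and not at a number, so no step between them can be read in this assay: the limit of > 300 mg/kg in this assay, at which 2 of the 4 values shown sit.

The compounds shown leave open whether any group at this place on the shared core would give a number in this assay.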